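Replacing 3-cyanophenyl in a three-compound series

The source may hold more compounds than are shown below. What is called first, only, known or untested is meant among the compounds shown, and "the series" means these compounds.

Measured in a functional assay on MCF7 cells (Homo sapiens) for cytotoxicity, read by CellTiter-Glo, with a stated time of 5 days; a higher number here means a weaker inhibitor, a lower number a stronger inhibitor:
compound 1 `CC/C(=C(/c1ccc(/C=C/C(=O)O)cc1)c1ccc2[nH]c(=O)oc2c1)c1ccccc1`: 56 nM
compound 2 `CC/C(=C(/c1ccc(/C=C/C(=O)O)nc1)c1ccc2[nH]ncc2c1)c1ccccc1`: 210 nM
compound 3 `CC/C(=C(/c1ccc(/C=C/C(=O)O)cc1)c1ccc2[nH]ncc2c1)c1cccc(C#N)c1`: 100 nM

Compound 3 (at 100 nM) carries the second highest of the three numbers. Its value lies within the usual scatter of compound 1 (at 56 nM). It is lower than that of compound 2 (at 210 nM), and that gap goes beyond the scatter.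

The next compound to be tested in this assay is compound 4 `CC/C(=C(/c1ccc(/C=C/C(=O)O)cc1)c1ccc2[nH]ncc2c1)c1ccc(C#N)cc1Cl`, which has 2-chloro-4-cyanophenyl in place of 3-cyanophenyl on a double-bonded chain carbon bound to a double-bonded chain carbon and a saturated chain carbon.

Going by the values given here, no two measured compounds differ in one place only, so the data give no direct measure of this change. The three values nevertheless sit fairly close together although the compounds differ in more than one place, which argues against expecting a large move away from compound 3 (at 100 nM). A modest shift toward a lower number is expected, though a result within the scatter would be no surprise. The expected size of the change is a 1.8-fold lower number from compound 3 to compound 4 (0.26 log units; within the scatter) in this estimate. Compound 4 is estimated at 55 nM (expected range 18 nM to 170 nM).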

Compound 4, half-maximal inhibitory concentration: 4 nM
The estimate for compound 4 lay 14-fold (1.14 log units) above the measured number; measured number outside the range, below it.
By their numbers in this assay, from the lowest: compound 4; then compounds 1 and 3 (each within the scatter of the next); then compound 2.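

In this assay, putting 2-chloro-4-cyanophenyl in place of 3-cyanophenyl on a double-bonded chain carbon bound to a double-bonded chain carbon and a saturated chain carbon gives a 25-fold lower number from compound 3 to compound 4 (1.40 log units; beyond the scatter) and this large step lies well beyond the scatter. Going by these compounds alone, the earlier compounds offered no pair that differed in one place only, so this is the first direct sign that the number in this assay responds strongly to the group at this place on the shared core. No measurement shown here offers an explanation for the size of this step.

The step combines two differences, a chlorine that enters and a nitrile named at 4 rather than 3, and a 4-cyanophenyl or 2-chlorophenyl group at this place would be needed to tell them apart. On these data alone, it also remains open whether fluorine or methyl in place of the chlorine would give a similar number, and whether the step would carry over to the other cores seen in compound 1 and compound 2.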